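Swapping the imidazole for benzimidazole in compound 4

The source may report more compounds than this note shows. Statements on the series, on what has been measured and on what is new or still open speak of the compounds shown alone.

Compound 3 `CC(C)c1nccn1CCC(C(N)=O)(c1ccccc1)c1ccccc1` stands lowest of the three numbers available in an assay on ileum with muscarinic acetylcholine receptor M3 (Cavia porcellus) as the target; on this read-out lower numbers stand for stronger inhibition and higher numbers for weaker inhibition: compound 3 gives 1.8 nM, while compound 2 `c1ccc(C(CCn2ccnc2)c2ccccc2)cc1` gives 89.1 nM and compound 1 `CCN(CC)CCC(c1ccccc1)c1ccccc1` gives 197 nM. The change to compound 4 `NC(=O)C(CCn1cnc2ccccc21)(c1ccccc1)c1ccccc1` is 1H-benzimidazol-1-yl in place of 2-isopropyl-1H-imidazol-1-yl on a saturated chain carbon, three bonds along the chain from two aromatic carbons and a carbonyl carbon. Among the measured compounds shown here, only one measured step concerns the same position on the chain: a 2.2-fold lower number from compound 1 to compound 2 (0.34 log units; beyond the scatter). For the measured compounds named here, that step replaced an amine by a heteroaromatic ring, whereas the present change exchanges one heteroaromatic ring for another, so it offers only an indirect guide, and no measured pair shows the effect of adding a fused benzene ring or of removing the isopropyl group. With so little to go on, the step of a 1.9-fold higher number from compound 3 to compound 4 (0.29 log units; within the scatter) from compound 3 to compound 4 is expected to be small, at most a modest rise that may not exceed the scatter. Compound 4 is therefore estimated at 3.5 nM, with a range from 1 nM to 12 nM.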

Compound 4, antagonist equilibrium constant: 2130 nM
Compound 4: the middle estimate sits 610-fold (2.78 log units) below what was measured; measured number above the stated range.
By their numbers in this assay, from the lowest: compound 3; then compound 2; then compound 1; then compound 4.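

In this assay, among the compounds shown here, the saturated chain carbon proves highly sensitive to which heteroaromatic ring it carries: a 1200-fold higher number from compound 3 to compound 4 (3.07 log units; beyond the scatter), much larger than the one earlier step at this place, on a core without the carbonyl group, a 2.2-fold lower number from compound 1 to compound 2 (0.34 log units; beyond the scatter). Putting 1H-benzimidazol-1-yl in place of 2-isopropyl-1H-imidazol-1-yl leaves the hydrogen-bond donors, hydrogen-bond acceptors and net charge as they were, so a change invisible in those counts can still produce a step of this size. No measurement at hand accounts for the step.

The change adds a fused benzene ring and removes the isopropyl group at once, and the compounds shown do not separate the two. A plain 1H-imidazol-1-yl or a 2-isopropyl-1H-benzimidazol-1-yl on the same chain carbon of the shared core would bear on that question.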